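The source may report more compounds than this note shows. Statements on the series, on what has been measured and on what is new or still open speak of the compounds shown alone.

Measured in an assay on isolated protein for inhibition of Lon protease homolog, mitochondrial (Homo sapiens), read by HTRF, with a stated time of 50 min, in the presence of a further agent that is not named here; on this read-out lower numbers stand for stronger inhibition and higher numbers for weaker inhibition:

compound 1 `CCC[C@@H](NC(=O)c1cnccn1)C(=O)N[C@@H](CC(C)C)B(O)O` gives 187 nM
compound 2 `CCC[C@@H](NC(=O)c1cnccn1)C(=O)N[C@@H](CC1CCCCC1)B(O)O` gives 136 nM
compound 3 `CCC[C@@H](NC(=O)c1cnccn1)C(=O)N[C@@H](CCCc1ccccc1)B(O)O` gives 17 nM

Compound 3 has the lowest number of the three in this assay; the others stand off by an 11-fold lower number from compound 1 to compound 3 (1.04 log units; beyond the scatter) and an 8.0-fold lower number from compound 2 to compound 3 (0.90 log units; beyond the scatter), both beyond the scatter, while a 1.4-fold lower number from compound 1 to compound 2 (0.14 log units; within the scatter) lies within it.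

Compound 4 `CCCC[C@H](NC(=O)[C@@H](CCC)NC(=O)c1cnccn1)B(O)O` is not yet measured. Relative to compound 3 the change is methyl in place of phenyl on a saturated chain carbon, four bonds along the chain from an amide-type nitrogen and a boron atom. It undoes the aromatic part of the group that separates compound 3 from compound 1 and compound 2; those two steps are the ones that bear on it. Each of them moved the number down by a large to modest amount when the aromatic group entered, so its removal is expected to move the number up in this assay, back toward the values of compound 1 and compound 2, though the retained chain length leaves some doubt about the full extent. The expected step is a 6.5-fold higher number from compound 3 to compound 4 (0.81 log units; beyond the scatter). For compound 4 the estimate in this assay is 110 nM, with a range from 40 nM to 300 nM.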

Compound 4, half-maximal inhibitory concentration: 38 nM
For compound 4 the middle estimate is 2.9-fold (0.46 log units) above the measured one; measured number below the stated range.
By their numbers in this assay, from the lowest: compound 3; then compound 4; then compounds 2 and 1 (each within the scatter of the next).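

In this assay, a straight chain without any ring already lowers the number well beyond the scatter: propyl in place of isopropyl gives a 4.9-fold lower number from compound 1 to compound 4 (0.69 log units; beyond the scatter), and propyl in place of cyclohexyl gives a 3.6-fold lower number from compound 2 to compound 4 (0.55 log units; beyond the scatter). The gain seen earlier with phenethyl therefore cannot be credited to the phenyl group alone, since removing that phenyl costs only a modest step, a 2.2-fold higher number from compound 3 to compound 4 (0.35 log units; beyond the scatter), and leaves the unbranched chain ahead of the isopropyl and cyclohexyl compounds. No measurement available here explains these differences.

Still open, from the compounds shown here alone, is whether a longer chain, such as hexyl, would close the remaining gap to compound 3 without any phenyl group. Also open, going by these compounds, is how an amine or a carboxylic acid at the end of this chain would read in this assay.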